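Moving a methyl around the amide-side phenyl ring

The compounds below may be only part of what the source reports. "The series", "measured", "known", "first", "only" and "open" are said of these compounds alone.

Measured so far in a functional assay on HeLa cells (Homo sapiens) for inhibition, read by MTT assay, with a stated time of 48 h; a lower number here means a stronger inhibitor, a higher number a weaker inhibitor:
Compound 1, `COc1ccc2c(=O)c(/C=C/C(=O)Nc3cccc(Cl)c3)coc2c1`: compound 1 gives 11900 nM.
Compound 2, `CCOc1ccc(NC(=O)/C=C/c2coc3cc(OC)ccc3c2=O)cc1`: for compound 2 the result is a limit of the assay, > 100000 nM.
Compound 3, `COc1ccc2c(=O)c(/C=C/C(=O)Nc3cccc(C)c3)coc2c1`: for compound 3 the result is also a limit of the assay, > 100000 nM.

Compound 3 thus has no number of its own; it sits at the limit of > 100000 nM in this assay, at which 2 of the 3 values shown sit, and only compound 1 carries a measured number.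

Compound 4 is `COc1ccc2c(=O)c(/C=C/C(=O)Nc3ccccc3C)coc2c1`. Its change from compound 3 is 2-methylphenyl in place of 3-methylphenyl on an amide-type nitrogen.

Among the compounds with values here, no measured step moves the methyl from one position of the ring to another. The nearest measured steps are an at least 8.4-fold higher number from compound 1 to compound 3 (0.92 log units; beyond the scatter) and an at least 8.4-fold higher number from compound 1 to compound 2 (0.92 log units; beyond the scatter); both change what sits on the ring rather than where it sits, and both end at the limit. The step that the two limits leave unreadable from compound 2 to compound 3 cannot be read because both ends are limits. With the starting point itself a limit, the expectation is that compound 4 stays near it, and the estimated step of a number no higher from compound 3 to compound 4 (the limit leaves the size open) is therefore small. The estimate for compound 4 is 100000 nM, with a range from 30000 nM to 300000 nM.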

Compound 4, half-maximal inhibitory concentration: 7270 nM
The estimate for compound 4 lay 14-fold (1.14 log units) above the measured number; measured number outside the range, below it.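

In this assay, moving the methyl around the ring is enough on its own to change the result: the two groups have the same atoms, joined differently, yet 2-methylphenyl in place of 3-methylphenyl gives an at least 13-fold lower number from compound 3 to compound 4 (1.13 log units; beyond the scatter). Within the data shown here, the earlier compounds could not show this, as they changed what sat on the ring rather than where it sat, and a methyl had so far given no measured number. Compound 4 now gives one, with an at least 13-fold lower number from compound 2 to compound 4 (1.13 log units; beyond the scatter), while a 1.6-fold lower number from compound 1 to compound 4 (0.21 log units; within the scatter) means that 2-methylphenyl and 3-chlorophenyl on the amide-type nitrogen cannot be told apart in this assay, so a chloro is not the only route to a measured number among these compounds.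

The true size of the first two steps stays open, since compound 2 and compound 3 each carry only a limit of the assay: the limit of > 100000 nM in this assay, at which 2 of the 4 values shown sit.

Also open, on these data alone, is whether an amine, a carboxylic acid or a longer chain in place of the methyl of 2-methylphenyl would keep, lower or lose the number seen for compound 4.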